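Replacing fluoro with methoxy on compound 1

The source may report more compounds than this note shows. Statements on the series, on what has been measured and on what is new or still open speak of the compounds shown alone.

Compound 1 `O=S(=O)(c1ccc(-c2cnc(C3CC3)o2)cc1)N1CCCOc2cc(F)ccc21` gives 42 nM
Compound 2 `O=S1(=O)CCCN(S(=O)(=O)c2ccc(-c3cnc(C4CC4)o3)cc2)c2ccccc21` gives 5880 nM

In a functional assay on PC-3 cells (Homo sapiens) for antiproliferative activity, read by MTT assay, with a stated time of 72 h (on this read-out lower numbers stand for stronger inhibition and higher numbers for weaker inhibition), compound 1 has the lower number of the two, so it shows the stronger inhibition, and its gap to compound 2 lies well beyond the usual scatter. Compound 3 `COc1ccc2c(c1)OCCCN2S(=O)(=O)c1ccc(-c2cnc(C3CC3)o2)cc1` keeps the rest of compound 1 but carries methoxy in place of fluoro on an aromatic carbon and the position of this group is the only difference. Among the compounds with values here, no measured pair shows this exchange, so the data offer no direct guide. In this assay a modest step toward weaker inhibition is expected, close to the edge of the scatter. The estimated size is a 2.0-fold higher number from compound 1 to compound 3 (0.31 log units; beyond the scatter) with considerable uncertainty. Compound 3 is estimated at 85 nM with an expected range from 20 nM to 400 nM until its measurement is known.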

Compound 3, half-maximal inhibitory concentration: 271 nM
Estimate against measurement, compound 3: 3.2-fold (0.50 log units) below; low and high end bracket the measured number.
By their numbers in this assay, from the lowest: compound 1; then compound 3; then compound 2.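

In this assay, within the data shown here, the exchange of fluoro for methoxy on this aromatic carbon gives the first direct reading of this position: a 6.5-fold higher number from compound 1 to compound 3 (0.81 log units; beyond the scatter). The step lies beyond the usual scatter, so inhibition of these cells does respond to which group sits here, and in this one pair the group with more heavy atoms and a hydrogen-bond acceptor goes with the weaker inhibition. No measurement at hand explains why this exchange weakens inhibition.

From the compounds shown here alone, with only fluoro and methoxy to compare, it remains open whether a plain hydrogen, chloro, a nitrile or an amine on this carbon would give a number nearer that of compound 1 or that of compound 3. Also open, going by these compounds, is whether the same exchange on another carbon of this aromatic ring would give a step of similar size.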